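The source may report more compounds than this note shows. Statements on the series, on what has been measured and on what is new or still open speak of the compounds shown alone.

The three measured compounds share one core and differ only in the length of a saturated chain bound to a carbonyl carbon. Compound 1 `CC(=O)OCc1ccc2oc(=O)c(C(=O)Oc3cccc(Br)c3)cc2c1` carries the shortest chain; in a functional assay on HT-1080 cells (Homo sapiens), read by transwell migration, with a stated time of 24 h, tested at 10 uM (a lower number here means a stronger effect, a higher number a weaker effect of the compound at the concentration tested), compound 1 gives 11.8%. Compound 2 `CCC(=O)OCc1ccc2oc(=O)c(C(=O)Oc3cccc(Br)c3)cc2c1` gives 21.3%, and compound 3 `CCCCC(=O)OCc1ccc2oc(=O)c(C(=O)Oc3cccc(Br)c3)cc2c1` gives 32.3%, the highest of the three numbers and therefore the weakest effect among them. The steps between them read a number 9.5 percentage points higher from compound 1 to compound 2 (within the scatter), a number 11 percentage points higher from compound 2 to compound 3 (beyond the scatter), and overall a number 20.5 percentage points higher from compound 1 to compound 3 (beyond the scatter); the first of these stays within the scatter, the other two go beyond it. Compound 4 `CCCCCC(=O)OCc1ccc2oc(=O)c(C(=O)Oc3cccc(Br)c3)cc2c1` lengthens the same chain once more: methyl in place of hydrogen on a saturated chain carbon, four bonds along the chain from a carbonyl carbon. All three measured steps bear on this change, since each adds carbon to the same chain, and the number has moved upward each time the chain grew by more than one carbon. A further modest rise in this assay is therefore expected, of about a number 7.7 percentage points higher from compound 3 to compound 4 (within the scatter). Compound 4 is thus estimated at 40%, within a range from 28% to 52%.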

Compound 4, a percentage reported as activity, at one concentration (the size of the read-out at that concentration, not a potency): 33.9%
Estimate against measurement, compound 4: 6.1 percentage points above; the measured number falls inside the stated range.
By their numbers in this assay, from the lowest: compounds 1 and 2 (each within the scatter of the next); then compounds 3 and 4 (each within the scatter of the next).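

In this assay, the rise seen as the chain grew from compound 1 to compound 3 does not clearly continue at this position: the added methyl gives a number 1.6 percentage points higher from compound 3 to compound 4 (within the scatter). The longer chain still stands apart from the two shortest, with a number 12.6 percentage points higher from compound 2 to compound 4 (beyond the scatter) and a number 22.1 percentage points higher from compound 1 to compound 4 (beyond the scatter), so the four compounds fall into two groups, compounds 1 and 2 at the lower numbers and compounds 3 and 4 at the higher ones. This small step also cannot be separated from the same methyl change made on the shortest chain: the same change on two cores in this assay, a number 9.5 percentage points higher (within the scatter) from compound 1 to compound 2 and a number 1.6 percentage points higher (within the scatter) from compound 3 to compound 4, 7.9 percentage points apart, within the scatter of two such steps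

Going by these compounds, whether the number stays level with a still longer chain, or shifts with a branched chain or with an amine or a carboxylic acid at the chain end, remains open. Readings at a single concentration also tell only how strong or weak the effect of each of the four compounds is at that concentration.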